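Arylacrylamide series at the melanin-concentrating hormone receptor

This account rests on a few compounds, and the source may have more. Where it says the series, first, only, none or still open, it means among the compounds named here.

Measured compounds: compound 1 `CCCc1ccc(/C=C/C(=O)Nc2ccc3nc(CCC)cc(N)c3c2)cc1` gives 4 nM; compound 2 `CCCc1cc(N)c2cc(NC(=O)/C=C/c3ccc(N)cc3)ccc2n1` gives 190 nM; compound 3 `CCCc1cc(N)c2cc(NC(=O)/C=C/c3ccc(SC)cc3)ccc2n1` gives 9 nM, all in an assay on isolated protein for displacement of a labelled ligand from melanin-concentrating hormone receptor 1 (Homo sapiens); on this read-out higher numbers stand for weaker inhibition and lower numbers for stronger inhibition.

Compound 3 stands second of the three numbers: its nearest neighbour is compound 1, separated by a 2.3-fold higher number from compound 1 to compound 3 (0.35 log units; beyond the scatter), and its furthest is compound 2, separated by a 21-fold lower number from compound 2 to compound 3 (1.32 log units; beyond the scatter). The first of these steps is modest, the second large, so the substituent at this end of the acrylamide clearly matters in this assay.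

Compound 4 `CCCc1cc(N)c2cc(NC(=O)/C=C/c3ccc(Cl)cc3Cl)ccc2n1` has not been measured. It differs from compound 3 by 2,4-dichlorophenyl in place of 4-(methylsulfanyl)phenyl on a double-bonded chain carbon bound to a double-bonded chain carbon. Among the compounds with values here, no measured step swaps a whole aryl group, so the steps that bear on it only indirectly are the two that also end at compound 3, a 2.3-fold higher number from compound 1 to compound 3 (0.35 log units; beyond the scatter) and a 21-fold lower number from compound 2 to compound 3 (1.32 log units; beyond the scatter), plus a 48-fold higher number from compound 1 to compound 2 (1.68 log units; beyond the scatter) between the other two. The entering group carries no donor or acceptor, which in the measured set was the case for propyl in compound 1 rather than for amino in compound 2. The expectation is therefore a small step, within or near the scatter, in either direction, written as a 1.1-fold higher number from compound 3 to compound 4 (0.05 log units; within the scatter). Compound 4 is estimated at 10 nM, with a range from 3 nM to 40 nM.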

Compound 4, half-maximal inhibitory concentration: 6.6 nM
Estimate against measurement, compound 4: 1.5-fold (0.18 log units) above; measured number inside the range.
By their numbers in this assay, from the lowest: compounds 1, 4 and 3 (each within the scatter of the next, the first and the last beyond it); then compound 2.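

In this assay, replacing the whole aryl group on a double-bonded chain carbon bound to a double-bonded chain carbon gives a 1.4-fold lower number from compound 3 to compound 4 (0.13 log units; within the scatter) and a 1.7-fold higher number from compound 1 to compound 4 (0.22 log units; within the scatter), so 2,4-dichlorophenyl cannot be told apart from either 4-(methylsulfanyl)phenyl or 4-propylphenyl. The hydrogen-bond acceptor counted in 4-(methylsulfanyl)phenyl is absent from 2,4-dichlorophenyl with no step beyond the scatter, so among these compounds that acceptor is not needed for a low number, and a ring carrying two chlorines fits the same narrow band as the rings with a single substituent. Compound 2 remains the one outlier, with a 29-fold lower number from compound 2 to compound 4 (1.46 log units; beyond the scatter) adding a third large step to its record, and nothing measured here gives a reason for this or for the level standing of the chlorinated ring.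

The compounds shown leave open whether a single chlorine, at either of the two places named in 2,4-dichlorophenyl, would read the same as the pair. They also leave open whether the large gap belongs to the free amine alone, which a dimethylamino group, an acetamide or a carboxylic acid in its place would begin to test.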